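Coumarin-Pyrazole Conjugates Tested for Antiproliferative Effect

The source may report more compounds than this note shows. Statements on the series, on what has been measured and on what is new or still open speak of the compounds shown alone.

Measured compounds:
compound 1, `Cc1nn(C)c(Oc2cccc(F)c2)c1/C=N\CCCCCOc1cc2oc(=O)cc(C)c2cc1Cl`, 13400 nM
compound 2, `Cc1nn(C)c(Oc2cccc(F)c2F)c1/C=N\CCCCCCOc1cc2oc(=O)cc(C)c2cc1Cl`, > 25000 nM

In a functional assay on HepG2 cells (Homo sapiens) for antiproliferative activity, read by MTT assay, with a stated time of 72 h (on this read-out higher numbers stand for weaker inhibition and lower numbers for stronger inhibition), compound 1 gives 13400 nM. For compound 2 the assay reports only a limit, > 25000 nM, so compound 2 stands at the limit of > 25000 nM in this assay, at which 1 of the 2 values shown sits, and no number is known for it. Compound 3, `Cc1ccc(Oc2c(/C=N\CCCCCCOc3cc4oc(=O)cc(C)c4cc3Cl)c(C)nn2C)cc1`, carries the change (4-methylphenyl in place of 2,3-difluorophenyl on an oxygen on an aromatic ring). For the measured compounds named here, with no measured step to go by, the size of the step from compound 2 cannot be set from the data. Compound 3 is expected to remain weak in this assay, with an estimated 22000 nM, between 8000 nM and 60000 nM, a step of an at least 1.1-fold lower number from compound 2 to compound 3 (0.05 log units; that floor lies within the scatter) that is expected to stay within the scatter.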

Compound 3, half-maximal inhibitory concentration: 20700 nM
Compound 3: the middle estimate sits 1.1-fold (0.03 log units) above what was measured, and the stated range covers the measured number.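

Placed on an oxygen on an aromatic ring, 4-methylphenyl in place of 2,3-difluorophenyl gives a measured number in this assay, with compound 3 at 20700 nM. For the compounds shown here, the change amounts to an at least 1.2-fold lower number from compound 2 to compound 3 (0.08 log units; that floor lies within the scatter), so it shows only that this ring can carry a methyl group instead of two fluorines with the compound remaining weak. The value of compound 2 is a limit and not a number: the limit of > 25000 nM in this assay, at which 1 of the 3 values shown sits.

From the compounds shown here alone, the true size of the step stays open. Also open, going by these compounds, is whether an amine or a carboxylic acid in place of the methyl group would move the number at all.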